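The compounds below may be only part of what the source reports. "The series", "measured", "known", "first", "only" and "open" are said of these compounds alone.

Working notes on the series. Compound 1 `O=C(Nc1ccccc1C(F)(F)F)C1CCc2ccccc2N1` carries a hydrogen on the ring nitrogen and one trifluoromethyl group; in a functional assay on HCT-15 cells (Homo sapiens) for cytotoxicity, read by sulforhodamine B assay, with a stated time of 72 h (on this read-out higher numbers stand for weaker inhibition of growth and lower numbers for stronger inhibition of growth), compound 1 gives 40400 nM. Compound 2 `CCC(=O)N1c2ccccc2CCC1C(=O)Nc1ccccc1C(F)(F)F` carries a propanoyl on that nitrogen. In this assay compound 2 reaches only > 80000 nM, which is a limit of the assay and not a number (the limit of > 80000 nM in this assay, at which 1 of the 3 values shown sits). The change hydrogen in place of propanoyl on a nitrogen on an aromatic ring in a ring gives an at least 1.9-fold lower number from compound 2 to compound 1 (0.29 log units; that floor lies within the scatter). Compound 3 `CCC(=O)N1c2ccccc2CCC1C(=O)Nc1cc(C(F)(F)F)cc(C(F)(F)F)c1` keeps the propanoyl and carries two trifluoromethyl groups; how its core differs from that of compound 2 is not broken down here. In this assay compound 3 gives 7620 nM, the lowest of the two measured numbers. Compound 4 `O=C(Nc1cc(C(F)(F)F)cc(C(F)(F)F)c1)C1CCc2ccccc2N1` is the hydrogen analogue of compound 3; the change is hydrogen in place of propanoyl on a nitrogen on an aromatic ring in a ring, the same change as made from compound 2 to compound 1, at the same place. A step of similar or modest size is expected for compound 4 because the earlier one gave an at least 1.9-fold lower number from compound 2 to compound 1 (0.29 log units; that floor lies within the scatter). For compound 4 in this assay the expected value is 4500 nM, between 1500 nM and 15000 nM, an estimated step of a 1.7-fold lower number from compound 3 to compound 4 (0.23 log units; within the scatter).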

Compound 4, concentration for 50% growth inhibition: 8700 nM
Compound 4: middle estimate off by 1.9-fold (0.29 log units), on the low side; measured number inside the range.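

In this assay, hydrogen in place of propanoyl on the core with two trifluoromethyl groups gives a 1.1-fold higher number from compound 3 to compound 4 (0.06 log units; within the scatter), so on this core the propanoyl can be removed without a step beyond the scatter. Compound 2 gives > 80000 nM, which is a limit of the assay and not a number. The two pairs do not show whether the change carries from one core to the other with the same size: the same change on two cores in this assay, an at least 1.9-fold lower number (0.29 log units; that floor lies within the scatter) from compound 2 to compound 1 and a 1.1-fold higher number (0.06 log units; within the scatter) from compound 3 to compound 4; the limit leaves it open whether they differ

The compounds shown leave open whether another group on that nitrogen, such as an acetyl, a longer acyl chain or a chain ending in a carboxylic acid, would give a step beyond the scatter on either core. Also open, going by these compounds, is whether a nitrile in place of the trifluoromethyl groups would leave the change from propanoyl to hydrogen as small as it is here.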